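The source may hold more compounds than are shown below. What is called first, only, known or untested is meant among the compounds shown, and "the series" means these compounds.

Of the compounds shown here, two sharing one core have been measured in an assay on isolated protein (strain Sprague-Dawley) for inhibition of Amine oxidase [flavin-containing] A (Rattus norvegicus), read by spectrophotometry, with a stated time of 5 min, tested at 10 uM; on this read-out lower numbers stand for less inhibition and higher numbers for more inhibition at the one concentration tested (going by the name of the read-out). Compound 1 `CN(C)C(=O)COc1cc(=O)oc2cc(OCc3cccc(Cl)c3)ccc12` gives 10% in this assay, and compound 2 `O=Cc1cc(=O)oc2cc(OCc3cccc(Cl)c3)ccc12` gives 14%. Between these two stands one step, a number 4 percentage points higher from compound 1 to compound 2 (within the scatter), so compound 2 is one of two numbers that lie within the usual scatter of each other, and the two numbers are level.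

Compound 3 `NC(=O)c1cc(=O)oc2cc(OCc3cccc(Cl)c3)ccc12` is not yet measured. It differs from compound 2 by amino in place of hydrogen on a carbonyl carbon. Within the data shown here, the only step known, a number 4 percentage points higher from compound 1 to compound 2 (within the scatter), swapped a larger group for the formyl at this same aromatic carbon without moving the number beyond the scatter. Because a number 4 percentage points higher from compound 1 to compound 2 (within the scatter) was that small, the expected step of no change at the digits printed from compound 2 to compound 3 (within the scatter) is also one that stays within the scatter, in no particular direction. Compound 3 is therefore estimated at 14%, with a range from 2% to 30%.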

Compound 3, a percentage reported as inhibition, at one concentration (the size of the read-out at that concentration, not a potency): 14%
For compound 3 middle estimate and measured number coincide at the digits printed; the measured number falls inside the stated range.
By their numbers in this assay, from the lowest: compounds 1, 2 and 3 (each within the scatter of the next).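

In this assay, the change from formyl to carbamoyl, with amino in place of hydrogen on a carbonyl carbon, gives no change at the digits printed from compound 2 to compound 3 (within the scatter), so adding this one nitrogen with its hydrogen-bond donor leaves the reading level. Set against the (dimethylcarbamoyl)methoxy group, the carbamoyl group gives a number 4 percentage points higher from compound 1 to compound 3 (within the scatter), which means that this aromatic carbon has now carried three different groups. None of the three separates from the others beyond the scatter, so the compounds shown offer no group at this place that stands out in this measurement.

On these data alone, whether a carboxylic acid, an amine or a longer chain on this aromatic carbon would move the number stays open. Nothing available explains why these three compounds read alike.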